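The source may report more compounds than this note shows. Statements on the series, on what has been measured and on what is new or still open speak of the compounds shown alone.

In an assay on CHO cells for displacement of a labelled ligand from adenosine receptor A3 (Homo sapiens), read by scintillation counting, with a stated time of 3 h (on this read-out higher numbers stand for weaker inhibition and lower numbers for stronger inhibition), compound 1 `Cc1nc(N)c2nc(-c3ccccc3)sc2n1` gives 2660 nM, the highest number among the three measured compounds. Compound 2 `Nc1nc(-c2cccc(CO)c2)nc2sc(-c3ccccc3)nc12` gives 3.7 nM and compound 3 `Nc1nc(-c2ccc(CO)cc2)nc2sc(-c3ccccc3)nc12` gives 8.2 nM. The step of a 720-fold lower number from compound 1 to compound 2 (2.86 log units; beyond the scatter) and the step of a 320-fold lower number from compound 1 to compound 3 (2.51 log units; beyond the scatter) are both large, while the step of a 2.2-fold higher number from compound 2 to compound 3 (0.35 log units; beyond the scatter) is modest. Compound 4 `Cc1nc(NC(=O)c2ccccc2)c2nc(-c3ccccc3)sc2n1` differs from compound 1 by benzoyl in place of hydrogen on a nitrogen on an aromatic ring. Going by the values given here, none of the measured steps touches this nitrogen; each of them alters the group on the aromatic carbon, so no measured step speaks directly to the new change. In this assay the number for compound 4 is therefore estimated at 400 nM, expected to fall between 60 nM and 3000 nM. The expected step, a 6.7-fold lower number from compound 1 to compound 4 (0.82 log units; beyond the scatter), carries wide uncertainty.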

Compound 4, inhibition constant: 691 nM
For compound 4 the middle estimate is 1.7-fold (0.24 log units) below the measured one, within the range that was stated.
By their numbers in this assay, from the lowest: compound 2; then compound 3; then compound 4; then compound 1.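

In this assay, going by these compounds alone, benzoyl in place of hydrogen on the nitrogen gives a 3.8-fold lower number from compound 1 to compound 4 (0.59 log units; beyond the scatter), the only measured step at this nitrogen. This nitrogen can therefore carry benzoyl without any loss of inhibition, and the number even falls. Nothing measured here explains that step. The compounds shown leave open whether an acetyl group or a longer chain on this nitrogen would do the same. They also leave open what benzoyl on this nitrogen does when 3-(hydroxymethyl)phenyl replaces the methyl on the aromatic carbon.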